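Ester chain variation on the shared core

The source may hold more compounds than are shown below. What is called first, only, known or untested is meant among the compounds shown, and "the series" means these compounds.

Compound 3 `COc1ccccc1OCC1SCCN1C(=O)CC(=O)O` gives 20 mg/kg in a functional assay on the whole organism for inhibition, with Cavia porcellus as the target (on this read-out higher numbers stand for an effect only at larger amounts of compound and lower numbers for an effect already at smaller amounts), the lowest of the three numbers, although compound 1 `CCOC(=O)CC(=O)N1CCSC1COc1ccccc1OC` with 21 mg/kg lies within the scatter of it; compound 2 `COc1ccccc1OCC1SCCN1C(=O)Cn1ccnc1` stands further off at 50 mg/kg, and a 2.5-fold lower number from compound 2 to compound 3 (0.40 log units; beyond the scatter). Compound 4 `CCOC(=O)C(C)(C)C(=O)N1CCSC1COc1ccccc1OC` differs from compound 3 by 1-(ethoxycarbonyl)-1-methylethyl in place of carboxymethyl on a carbonyl carbon. Among the measured compounds shown here, the only measured step that bears on this is the ester-to-acid exchange, a 1.1-fold lower number from compound 1 to compound 3 (0.02 log units; within the scatter), which stayed within the scatter; the 1-(ethoxycarbonyl)-1-methylethyl group itself has no precedent among the measured compounds. On this basis the step of a 1.3-fold higher number from compound 3 to compound 4 (0.10 log units; within the scatter) is expected to stay within the scatter or reach at most a modest rise. Compound 4 is estimated at 25 mg/kg, with a range from 10 mg/kg to 60 mg/kg.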

Compound 4, dose for half-maximal effect: 61 mg/kg
Compound 4: the middle estimate sits 2.4-fold (0.39 log units) below what was measured; the measured number lies above the stated range.
By their numbers in this assay, from the lowest: compounds 3 and 1 (each within the scatter of the next); then compounds 2 and 4 (each within the scatter of the next).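

In this assay, with the ethoxycarbonyl kept, the change to 1-(ethoxycarbonyl)-1-methylethyl gives a 2.9-fold higher number from compound 1 to compound 4 (0.46 log units; beyond the scatter), so this position responds to a change in the chain even where the ester-to-acid exchange did not move the number. The step of a 3.1-fold higher number from compound 3 to compound 4 (0.48 log units; beyond the scatter) is of similar size, while a 1.2-fold higher number from compound 2 to compound 4 (0.09 log units; within the scatter) leaves the two compounds level. No measurement shown gives a reason for this rise.

Open, on these data alone, is whether the matching acid, 1-carboxy-1-methylethyl, would read like compound 3 or like compound 4. Also open, as far as these compounds go, is how an amine or a longer chain would read in this place.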